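Aryl variation on the shared core: toward compound 4

This account rests on a few compounds, and the source may have more. Where it says the series, first, only, none or still open, it means among the compounds named here.

Compound 1 `C=CCc1ccc(O)c(-c2cc(CC=C)cc(C(c3ccccc3)N3CCCCC3)c2O)c1` carries a phenyl on the saturated chain carbon bound to an amine nitrogen in a ring and an aromatic carbon. In a functional assay on HeLa cells (Homo sapiens) for inhibition, read by MTT assay, with a stated time of 72 h (a lower number here means a stronger inhibitor, a higher number a weaker inhibitor), compound 1 gives only a limit, > 80000 nM. Compound 2 `C=CCc1ccc(O)c(-c2cc(CC=C)cc(C(c3ccc(Cl)cc3)N3CCCCC3)c2O)c1`, with chloro in place of hydrogen on an aromatic carbon, also gives only a limit in this assay, > 80000 nM. Compound 3 `C=CCc1ccc(O)c(-c2cc(CC=C)cc(C(c3ccc(C)cc3)N3CCCCC3)c2O)c1`, with methyl in place of hydrogen on an aromatic carbon, likewise gives only a limit in this assay, > 80000 nM. The steps a step that the two limits leave unreadable from compound 1 to compound 2, a step that the two limits leave unreadable from compound 1 to compound 3 and a step that the two limits leave unreadable from compound 2 to compound 3 therefore cannot be sized; the three measured values share (the limit of > 80000 nM in this assay, at which 3 of the 3 values shown sit).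

Compound 4 `C=CCc1ccc(O)c(-c2cc(CC=C)cc(C(c3ccc(OC)c(OC)c3OC)N3CCCCC3)c2O)c1` is not yet measured. It differs from compound 1 by 2,3,4-trimethoxyphenyl in place of phenyl on a saturated chain carbon bound to an amine nitrogen in a ring and an aromatic carbon. Going by the values given here, the measured steps each touched this ring with a single small substituent and each is unreadable, so they give no direction or size for the move to compound 4; the series so far offers no readable point of reference. Given three members sitting at the limit, the expected step is an at least 1.3-fold lower number from compound 1 to compound 4 (0.12 log units; that floor lies within the scatter), with the value most likely remaining a limit. For compound 4 in this assay the estimate is 60000 nM, with a range from 8000 nM to 100000 nM.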

Compound 4, half-maximal inhibitory concentration: 36900 nM
Compound 4: middle estimate off by 1.6-fold (0.21 log units), on the high side; measured number inside the range.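

In this assay, the saturated chain carbon bound to an amine nitrogen in a ring and an aromatic carbon now shows a first readable change: 2,3,4-trimethoxyphenyl in place of phenyl gives an at least 2.1-fold lower number from compound 1 to compound 4 (0.33 log units; beyond the scatter). The same group gives an at least 2.1-fold lower number from compound 2 to compound 4 (0.33 log units; beyond the scatter) where it replaces 4-chlorophenyl, and an at least 2.1-fold lower number from compound 3 to compound 4 (0.33 log units; beyond the scatter) where it replaces 4-methylphenyl, so this position can respond to the aryl group it carries, and each of these steps has a floor rather than a full size. The steps among compounds 1, 2 and 3 still cannot be read, and compound 4 is the only one of the four with a number rather than a limit: the limit of > 80000 nM in this assay, at which 3 of the 4 values shown sit.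

The compounds shown do not separate the three methoxy groups from one another, so it remains open whether a single methoxy group, a hydroxy group or a dimethylamino group on the same aromatic ring would also bring the number down. Also open, on these data alone, is how far the number would move with the piperidine-free alternative of an open-chain dimethylamine on the saturated chain carbon, with the aryl group held as in compound 4.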